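From compound 2 to compound 3: one added chloro

The compounds below may be only part of what the source reports. "The series", "measured", "known", "first", "only" and "open" are said of these compounds alone.

Compound 1 `CC(=O)SCCC(CCCCC(=O)O)SC(C)=O`: 8.88%
Compound 2 `CC(=O)SCCC(CCCCC(=O)Nc1ccccc1)SC(C)=O`: 2.5%

Both compounds were tested in a functional assay on KB cells (Homo sapiens) for inhibition, read by MTT assay, with a stated time of 24 h, tested at 10 ug/mL; a higher number here means more inhibition of growth at the concentration tested, a lower number less inhibition of growth. In this assay, among the measured compounds shown here, compound 2 gives 2.5%, a number within the scatter of the one other measured compound. Compound 3 `CC(=O)SCCC(CCCCC(=O)Nc1ccccc1Cl)SC(C)=O` has not yet been measured. It differs from compound 2 by one change: chloro in place of hydrogen on an aromatic carbon. This is chloro in place of hydrogen on an aromatic carbon, which turns anilino into (2-chlorophenyl)amino.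

For the measured compounds named here, only one measured step is available as a guide: a number 6.4 percentage points lower from compound 1 to compound 2 (within the scatter). Going by the values given here, that step involves a different change, and no measured step shows what a chloro group does here. A shift beyond the scatter is therefore not expected. The estimated step is a number 2.5 percentage points higher from compound 2 to compound 3 (within the scatter). For compound 3 the expected value is 5%, with an estimated range from 0% to 14%.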

Compound 3, percent growth inhibition at one concentration: 6.55%
For compound 3 the middle estimate is 1.6 percentage points below the measured one; low and high end bracket the measured number.
By their numbers in this assay, from the lowest: compounds 2, 3 and 1 (each within the scatter of the next).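

Chloro in place of hydrogen, ortho to a large group on the six-membered aromatic ring, gives a number 4.1 percentage points higher from compound 2 to compound 3 (within the scatter) in this assay, so this one added atom leaves compound 3 indistinguishable from compound 2. Replacing the hydroxy on the carbonyl carbon with (2-chlorophenyl)amino gives a number 2.3 percentage points lower from compound 1 to compound 3 (within the scatter), so compound 3 also cannot be told apart from compound 1, and all three compounds now sit within the scatter of the next. Nothing measured here offers an explanation for these numbers.

As far as these compounds go, what a methoxy, a nitrile or a trifluoromethyl group on this same aromatic carbon would do remains open. It is also unknown whether a longer chain in the shared core, or an amine in place of the anilino group, would give a number beyond the scatter.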